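The source may hold more compounds than are shown below. What is called first, only, known or untested is meant among the compounds shown, and "the series" means these compounds.

In a functional assay on cells (Platelet, Homo sapiens) for inhibition (on this read-out higher numbers stand for weaker inhibition and lower numbers for stronger inhibition), compound 1 `CCOC(=O)c1cccc(-c2n[nH]c3ccccc23)c1` gives only a limit, > 10000 nM. Compound 2 `CCOC(=O)c1ccc(-c2nn(C)c3ccccc23)cc1` likewise gives only a limit, > 10000 nM. Compound 3 `CCOC(=O)c1ccc(-c2nn(Cc3ccc(Cl)cc3)c3ccccc23)cc1` also stands at a limit, > 10000 nM, so it offers no number to start from. Compound 4 `CCOC(=O)c1ccc(-c2nn(Cc3ccc(F)cc3)c3ccccc23)cc1` carries fluoro in place of chloro on an aromatic carbon, para to a large group: fluoro in place of chloro on an aromatic carbon. For the measured compounds named here, the one measured step that bears on this change, a step that the two limits leave unreadable from compound 2 to compound 3, has no readable size. All the evidence so far is the limit of > 10000 nM in this assay, at which 3 of the 3 values shown sit. No size or direction can therefore be expected with any confidence in this assay, and the estimated step is a step that the limit leaves unreadable from compound 3 to compound 4. Compound 4 is estimated at 15000 nM, with an expected range from 5000 nM to 50000 nM.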

Compound 4, half-maximal inhibitory concentration: > 10000 nM
Compound 4 ended at the assay's limit; the forecaster's own chance of this, stated with the estimate: 85%; the middle value does not contradict the limit.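

In this assay compound 4 gives only a limit, > 10000 nM. No new step can be read between compound 4 and compound 2 or compound 3. The compounds shown leave open how strongly any of them inhibits, since all stand at one limit: the limit of > 10000 nM in this assay, at which 4 of the 4 values shown sit.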